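The source may report more compounds than this note shows. Statements on the series, on what has been measured and on what is new or still open speak of the compounds shown alone.

Compound 1, `CC(C)(C)c1cc(-c2cc(=O)c3ccc(OCC(=O)N4CCN(Cc5ccccc5)CC4)cc3o2)cc(C(C)(C)C)c1O`, and compound 2, `CC(C)(C)c1cc(-c2cc(=O)c3ccc(OCC(=O)N4CCCCC4)cc3o2)cc(C(C)(C)C)c1O`, share one core and differ only in the group sitting on a saturated chain carbon bound to an oxygen on an aromatic ring. In a functional assay for inhibition (a higher number here means a weaker inhibitor, a lower number a stronger inhibitor), compound 1 gives 3000 nM, and in this assay compound 2 gives 3000 nM. Compound 2 therefore stands level with compound 1, and the difference between them lies within the scatter. Compound 3, `COc1ccc2c(=O)cc(-c3cc(C(C)(C)C)c(O)c(C(C)(C)C)c3)oc2c1`, carries hydrogen in place of (piperidin-1-yl)carbonyl on a saturated chain carbon bound to an oxygen on an aromatic ring. Among the measured compounds shown here, no measured pair shows the effect of removing this group, so its direction is not known from the data. Because compound 1 gives 3000 nM while compound 2 gives 3000 nM with different groups at that position, that end of the molecule appears to contribute little. The step expected in this assay is no change at the digits printed from compound 2 to compound 3 (within the scatter), meaning no change beyond the scatter. Compound 3 is estimated at 3000 nM, with a range from 1000 nM to 10000 nM.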

Compound 3, half-maximal inhibitory concentration: 1000 nM
Beside the measured number, compound 3's estimate is 3.0-fold (0.48 log units) above it, and the stated range covers the measured number.
By their numbers in this assay, from the lowest: compound 3; then compounds 1 and 2 (each within the scatter of the next).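

Replacing (piperidin-1-yl)carbonyl with hydrogen on a saturated chain carbon bound to an oxygen on an aromatic ring turns ((piperidin-1-yl)carbonyl)methoxy into plain methoxy, and in this assay this gives a 3.0-fold lower number from compound 2 to compound 3 (0.48 log units; beyond the scatter). The earlier pair suggested that this end of the molecule contributes little, but this step shows that it can affect the result: the simpler methoxy compound is the stronger inhibitor, so the larger amide group is not needed for inhibition at this level. Nothing available explains why the number moves.

The compounds shown leave open which part of the lost group accounts for the step. A carboxylic acid on that same chain carbon, or a longer chain such as ethoxy in place of methoxy, could land near either compound 2 or compound 3.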